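This account rests on a few compounds, and the source may have more. Where it says the series, first, only, none or still open, it means among the compounds named here.

Compound 1 `COc1cc(C(F)(F)F)ccc1-c1cccc2cc(S(=O)(=O)Nc3ccncn3)ccc12`: < 14 mL.min-1.g-1 (a limit)
Compound 2 `COc1cc(C(F)(F)F)ccc1-c1cccc2cc(S(=O)(=O)Nc3ccccn3)ccc12`: 16 mL.min-1.g-1

Within the data shown here, in an ADME assay on liver (Homo sapiens) for metabolic stability, read by LC-MS, using microsomes and NADPH, with a stated time of 40 min, tested at 1 uM (on this read-out lower numbers stand for slow clearance and higher numbers for fast clearance), compound 2 holds the only actual number, 16 mL.min-1.g-1. For compound 1 the assay reports only a limit. Compound 3 `COc1cc(C(F)(F)F)ccc1-c1cccc2cc(S(=O)(=O)Nc3ncccn3)ccc12` has pyrimidin-2-yl in place of pyridin-2-yl on a sulfonamide nitrogen. Among the measured compounds shown here, the one measured step that bears on this change is an at least 1.1-fold higher number from compound 1 to compound 2 (0.05 log units; that floor lies within the scatter), where pyridin-2-yl replaced pyrimidin-4-yl at the same place. On that evidence, no step beyond the scatter is expected, and the estimate is a 1.1-fold lower number from compound 2 to compound 3 (0.06 log units; within the scatter). Compound 3 is expected at 14 mL.min-1.g-1, with an estimated range of 7 mL.min-1.g-1 to 28 mL.min-1.g-1.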

Compound 3, intrinsic clearance in microsomes: 17 mL.min-1.g-1
For compound 3 the middle estimate is 1.2-fold (0.08 log units) below the measured one; low and high end bracket the measured number.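

Pyrimidin-2-yl in place of pyridin-2-yl on a sulfonamide nitrogen gives a 1.1-fold higher number from compound 2 to compound 3 (0.03 log units; within the scatter) in this assay and thus, unlike the earlier pair, puts two actual numbers side by side, so a second ring nitrogen here leaves the read-out within the scatter. From pyrimidin-4-yl to pyrimidin-2-yl the result is an at least 1.2-fold higher number from compound 1 to compound 3 (0.08 log units; that floor lies within the scatter) and this is only a floor, because compound 1 carries a limit: the limit of < 14 mL.min-1.g-1 in this assay, at which 1 of the 3 values shown sits.

What the compounds shown leave open is whether phenyl, with no ring nitrogen, or a carboxylic acid at this place would move clearance beyond the scatter.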